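Removing the Benzyloxycarbonyl from the Trimethoxyphenyl Analogue

This account rests on a few compounds, and the source may have more. Where it says the series, first, only, none or still open, it means among the compounds named here.

Compound 2 `O=C(OCc1ccccc1)N1CCN(C(=S)SCc2cn(Cc3ccc(F)cc3)nn2)CC1` is the only one of these three with a numeric result: in a functional assay on ECa-109 cells (Homo sapiens) for inhibition, read by MTT assay, with a stated time of 72 h (a lower number here means a stronger inhibitor, a higher number a weaker inhibitor), compound 2 gives 32000 nM. Compound 1 `Fc1ccc(Cn2cc(CSC(=S)N3CCNCC3)nn2)cc1` differs from it by hydrogen in place of benzyloxycarbonyl on an amine nitrogen in a ring. In this assay compound 1 gives > 128000 nM, which is a limit of the assay rather than a number. That step is an at least 4.0-fold higher number from compound 2 to compound 1 (0.60 log units; beyond the scatter). Compound 3 `COc1cc(Cn2cc(CSC(=S)N3CCN(C(=O)OCc4ccccc4)CC3)nn2)cc(OC)c1OC` carries a different core, differing from compound 2 by 3,4,5-trimethoxyphenyl in place of 4-fluorophenyl on a saturated chain carbon bound to an aromatic nitrogen. In this assay compound 3 gives > 128000 nM, again only a limit. That step is an at least 4.0-fold higher number from compound 2 to compound 3 (0.60 log units; beyond the scatter). Compound 4 `COc1cc(Cn2cc(CSC(=S)N3CCNCC3)nn2)cc(OC)c1OC` has not been measured; it differs from compound 3 by hydrogen in place of benzyloxycarbonyl on an amine nitrogen in a ring, the same change made at the same place. The expected step is a step that the limit leaves unreadable from compound 3 to compound 4, resting on compound 3 already sitting at the limit of > 128000 nM in this assay, at which 2 of the 3 values shown sit, and on the weakening seen in an at least 4.0-fold higher number from compound 2 to compound 1 (0.60 log units; beyond the scatter). Compound 4 is therefore expected to come out near 250000 nM in this assay.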

Compound 4, half-maximal inhibitory concentration: > 128000 nM
Compound 4: no number, only a limit; the forecaster's own chance of this, stated with the estimate: 85%; the middle value is on the limit's open side.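

In this assay compound 4 gives > 128000 nM, which is a limit and not a number. Compound 3 also stands at a limit, so the step from compound 3 to compound 4 cannot be read: the limit of > 128000 nM in this assay, at which 3 of the 4 values shown sit.

From the compounds shown here alone, what hydrogen in place of benzyloxycarbonyl does to the potency of the 3,4,5-trimethoxyphenyl compounds stays open.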